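Side-chain variation on the shared core: compound 4

A few compounds are considered here, and "the series" means these few. Any claim that something is new, unique, unknown or untested is made for them only; others in the source may bear on it.

Compound 1 `Cn1ncc(Cl)c1-c1cc(C(=O)N[C@@H]2CN[C@H](CCN3CCC(O)CC3)C[C@H]2c2ccc(Cl)c(Cl)c2)oc1Cl` carries the (4-hydroxypiperidin-1-yl)methyl group; in an assay for inhibition of RAC-alpha serine/threonine-protein kinase (Homo sapiens), read by HTRF, with a stated time of 1 h (on this read-out higher numbers stand for weaker inhibition and lower numbers for stronger inhibition), compound 1 gives 5.99 nM, the highest of the three numbers shown. Compound 2 `Cn1ncc(Cl)c1-c1cc(C(=O)N[C@@H]2CN[C@H](CC(N)=O)C[C@H]2c2ccc(Cl)c(Cl)c2)oc1Cl` gives 3.24 nM and compound 3 `Cn1ncc(Cl)c1-c1cc(C(=O)N[C@@H]2CN[C@H](CCO)C[C@H]2c2ccc(Cl)c(Cl)c2)oc1Cl` gives 2.74 nM. The steps from compound 1 are a 1.8-fold lower number from compound 1 to compound 2 (0.27 log units; within the scatter) and a 2.2-fold lower number from compound 1 to compound 3 (0.34 log units; beyond the scatter); between the two replacements the step is a 1.2-fold lower number from compound 2 to compound 3 (0.07 log units; within the scatter). Compound 4 `Cn1ncc(Cl)c1-c1cc(C(=O)N[C@@H]2CN[C@H](CC(=O)NC3CCC3)C[C@H]2c2ccc(Cl)c(Cl)c2)oc1Cl` differs from compound 1 by cyclobutylcarbamoyl in place of (4-hydroxypiperidin-1-yl)methyl on a saturated chain carbon bound to a saturated ring carbon. Within the data shown here, the nearest measured precedent is the change to the plain carbamoyl, a 1.8-fold lower number from compound 1 to compound 2 (0.27 log units; within the scatter), a small downward move; the cyclobutyl on the amide nitrogen has no measured counterpart here. For compound 4 a step of about that size, or none beyond the scatter, is expected, a 1.5-fold lower number from compound 1 to compound 4 (0.18 log units; within the scatter). Compound 4 is accordingly estimated at 4 nM, within 1.5 nM to 11 nM.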

Compound 4, half-maximal inhibitory concentration: 7.98 nM
The estimate for compound 4 lay 2.0-fold (0.30 log units) below the measured number, within the range that was stated.
By their numbers in this assay, from the lowest: compounds 3, 2, 1 and 4 (each within the scatter of the next, the first and the last beyond it).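

In this assay, cyclobutyl in place of hydrogen on the amide-type nitrogen gives a 2.5-fold higher number from compound 2 to compound 4 (0.39 log units; beyond the scatter) and shows that this position does not treat the plain and the substituted amide alike. The comparison with the hydroxymethyl side chain gives a 2.9-fold higher number from compound 3 to compound 4 (0.46 log units; beyond the scatter), whereas a 1.3-fold higher number from compound 1 to compound 4 (0.12 log units; within the scatter) leaves compound 4 and compound 1 indistinguishable. No measurement shown accounts for these steps.

Going by these compounds, whether the rise on the amide nitrogen tracks the size of the group remains open. A methyl or cyclohexyl group on that nitrogen, or a carboxylic acid in place of the carbamoyl, would test this position further.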